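This account rests on a few compounds, and the source may have more. Where it says the series, first, only, none or still open, it means among the compounds named here.

Working notes on the series, two compounds measured so far in a physicochemical assay for solubility, in phosphate buffer, measured as kinetic solubility, with a stated time of 1 h, at pH 7.4; a higher number here means a more soluble compound, a lower number a less soluble compound. Compound 1 `COc1ccc2nc(C)cc(OCC(=O)Nc3cc(C)ccc3OC)c2c1` gives 9500 nM in this assay. Within the data shown here, compound 2 `COc1ccc2nc(C)cc(OCC(=O)Nc3ccc(Cl)cc3Cl)c2c1` gives 20500 nM in this assay and so stands highest of the two numbers; the one measured step, a 2.2-fold higher number from compound 1 to compound 2 (0.33 log units; beyond the scatter), runs between them, beyond the scatter.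

Compound 3 `COc1ccc2nc(C)cc(OCC(=O)Nc3cccnc3)c2c1` differs from compound 2 in one place: pyridin-3-yl in place of 2,4-dichlorophenyl on an amide-type nitrogen. Among the measured compounds shown here, no measured step covers this replacement; the single step from compound 1 to compound 2 concerns a different group on the same amide-type nitrogen and is of modest size, so it shows only that a change of the group on this nitrogen can move the number beyond the scatter.

With nothing measured that bears on pyridin-3-yl itself, the expectation is held close to compound 2 and kept wide. Compound 3 is estimated at 40000 nM in this assay, within 12000 nM to 130000 nM, which would mean a step of a 2.0-fold higher number from compound 2 to compound 3 (0.29 log units; within the scatter), expected to be upward but not securely beyond the scatter.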

Compound 3, solubility: 32000 nM
Estimate against measurement, compound 3: 1.3-fold (0.10 log units) above; the measured number falls inside the stated range.
By their numbers in this assay, from the lowest: compound 1; then compounds 2 and 3 (each within the scatter of the next).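

In this assay, pyridin-3-yl in place of 2,4-dichlorophenyl on the amide-type nitrogen gives a 1.6-fold higher number from compound 2 to compound 3 (0.19 log units; within the scatter), so these two groups, one a six-membered aromatic ring with 1 hetero atom and the other a ring of carbon only carrying two chlorine atoms, are not told apart at this position. Pyridin-3-yl in place of 2-methoxy-5-methylphenyl gives a 3.4-fold higher number from compound 1 to compound 3 (0.53 log units; beyond the scatter), which lies beyond the scatter, as does a 2.2-fold higher number from compound 1 to compound 2 (0.33 log units; beyond the scatter), so two different replacements of the 2-methoxy-5-methylphenyl group on this nitrogen each give a higher number among the three listed compounds, and no listed compound goes against this. No measured property of these groups is available to account for either step.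

Still open, on these data alone, is how a group of another kind on the amide-type nitrogen would read in this assay, for example a chain ending in an amine, a phenyl ring carrying a carboxylic acid, or a saturated ring such as piperidine. The three compounds also share one core, so they say nothing about whether these steps would keep their size on a different core.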